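A few compounds are considered here, and "the series" means these few. Any claim that something is new, unique, unknown or untested is made for them only; others in the source may bear on it.

Compound 1 `CC(=O)Nc1cccc(C2CCN(CCCn3c(-c4ccc(F)cc4)nc4ccccc43)CC2)c1`: 56 nM
Compound 2 `CC(=O)Nc1cccc(C2CCN(CCCn3c(-c4ccc(Br)cc4)nc4ccccc43)CC2)c1`: 5 nM

Going by the values given here, in an assay for displacement of a labelled ligand from melanin-concentrating hormone receptor 1 (Homo sapiens), read by fluorescence (a higher number here means a weaker inhibitor, a lower number a stronger inhibitor), compound 2 gives 5 nM, the lowest of the two numbers measured so far, while compound 1 gives 56 nM. Among the compounds with values here, the only measured step, an 11-fold lower number from compound 1 to compound 2 (1.05 log units; beyond the scatter), is large and lies beyond the scatter: swapping one halogen for another on this ring moved the number a long way. Compound 3 `CC(=O)Nc1cccc(C2CCN(CCCn3c(-c4ccc(Cl)cc4F)nc4ccccc43)CC2)c1` has not yet been measured in this assay. It differs from compound 2 in one place: 4-chloro-2-fluorophenyl in place of 4-bromophenyl on an aromatic carbon. The step from compound 1 to compound 2 bears on this change, because an 11-fold lower number from compound 1 to compound 2 (1.05 log units; beyond the scatter) shows how strongly the halogen on that ring matters. Here the bromine gives way to chlorine, and a fluorine is added besides; no measured pair shows what that added fluorine does, and no measured compound carries chlorine on this ring. The expectation is a step of a 2.4-fold higher number from compound 2 to compound 3 (0.38 log units; beyond the scatter) in this assay, the number rising moderately, most likely near the edge of the scatter. Compound 3 is therefore estimated to give about 12 nM, within a range from 4 nM to 40 nM.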

Compound 3, half-maximal inhibitory concentration: 1 nM
Compound 3: the middle estimate sits 12-fold (1.08 log units) above what was measured; measured number outside the range, below it.
By their numbers in this assay, from the lowest: compound 3; then compound 2; then compound 1.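

In this assay, the change from 4-bromophenyl to 4-chloro-2-fluorophenyl gives a 5.0-fold lower number from compound 2 to compound 3 (0.70 log units; beyond the scatter), so bromine is not needed for a low number, and this position, on an aromatic carbon between two ring nitrogen atoms, can go lower than compound 2 did. The change from the 4-fluorophenyl group gives a 56-fold lower number from compound 1 to compound 3 (1.75 log units; beyond the scatter), and compound 3 now has the lowest number of the three, with its steps to both others beyond the scatter. Two things changed together on the ring, chlorine taking the place of bromine and a fluorine being added, and nothing available explains the fall in the number.

As far as these compounds go, what stays open is how much of the step belongs to the chlorine and how much to the added fluorine, a question that a plain 4-chlorophenyl group at this position would help to separate. From the compounds shown here alone, it is also open whether other groups on this ring, such as methoxy or trifluoromethyl, would hold the number this low or lose what the halogens gained.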